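A few compounds are considered here, and "the series" means these few. Any claim that something is new, unique, unknown or untested is made for them only; others in the source may bear on it.

In an assay on HEK-293T cells for inhibition of diacylglycerol lipase-alpha (Homo sapiens), read by colorimetric assay (a lower number here means a stronger inhibitor, a higher number a weaker inhibitor), three compounds have been measured so far. Compound 1, `O=C(CCCCCc1ccccc1)c1nc2ccccc2s1`, gives > 10000 nM, which is a limit of the assay rather than a number. Compound 2, `O=C(CCCCCc1ccccc1)c1nc2ccc(F)cc2o1`, gives 708 nM. Compound 3, `O=C(CCCCCCc1ccccc1)c1ncc(-c2ccco2)s1`, gives > 10000 nM, again a limit and not a measured number. Compound 3 therefore stands at the edge of what the assay can report, and it shares that position with one other compound, as seen from the limit of > 10000 nM in this assay, at which 2 of the 3 values shown sit.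

Compound 4 is `O=C(CCCCCCc1ccccc1)c1ncc(-c2cccs2)s1`. It differs from compound 3 in one place: thiophen-2-yl in place of furan-2-yl on an aromatic carbon of a five-membered aromatic ring with one nitrogen and one sulfur. Among the compounds with values here, no measured pair among the compounds above differs in just this way, so no step can be read off for this swap in this assay. The expectation is that compound 4 stays close to where compound 3 sits, with an estimated step that the limit leaves unreadable from compound 3 to compound 4 from that limit, not beyond the usual scatter in either direction. Compound 4 is accordingly estimated at 15000 nM, with a range from 3000 nM to 60000 nM.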

Compound 4, half-maximal inhibitory concentration: > 10000 nM
Compound 4 gave a limit, no number (the forecaster's own chance of this, stated with the estimate: 70%); the middle value does not contradict the limit.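

In this assay compound 4 gives > 10000 nM which is a limit and not a number. Compound 3 also sits at a limit, so no step can be read from compound 3 to compound 4, and both stay at the edge of what the assay reports: the limit of > 10000 nM in this assay, at which 3 of the 4 values shown sit.

As far as these compounds go, how strongly either compound inhibits, and whether thiophen-2-yl and furan-2-yl differ at all here, stays open.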